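From Methyl to Benzyl: Does Growth Inhibition Hold?

A few compounds are considered here, and "the series" means these few. Any claim that something is new, unique, unknown or untested is made for them only; others in the source may bear on it.

Among the compounds with values here, in a functional assay on HL-60 cells (Homo sapiens) for inhibition, read by MTT assay, with a stated time of 72 h, tested at 50 uM (a lower number here means less inhibition of growth, a higher number more inhibition of growth at the concentration tested), compound 1 `C=CCc1cc(O)c(O)c(CN2CCC(C)CC2)c1` gives 91.8%, the higher of the two numbers so far and beyond the scatter of compound 2 `C=CCc1ccc(OCc2cn(-c3cc(OC)c(OC)c(OC)c3)nn2)c(O)c1`, which gives 41.4%. Compound 3 `C=CCc1cc(O)c(O)c(CN2CCC(Cc3ccccc3)CC2)c1` differs from compound 1 in one place: phenyl in place of hydrogen on a saturated chain carbon bound to a saturated ring carbon. This turns methyl into benzyl. Within the data shown here, no measured pair shows what such a change does. In this assay, a small fall or none beyond the scatter is expected, since compound 1 at 91.8% has little room to rise. The estimated change is a number 5.8 percentage points lower from compound 1 to compound 3 (within the scatter). Compound 3 is expected to give 86%, within a range of 62% to 100%.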

Compound 3, percent growth inhibition at one concentration: 94.4%
Beside the measured number, compound 3's estimate is 8.4 percentage points below it; measured number inside the range.
By their numbers in this assay, from the lowest: compound 2; then compounds 1 and 3 (each within the scatter of the next).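

In this assay, the change from methyl to benzyl gives a number 2.6 percentage points higher from compound 1 to compound 3 (within the scatter), so this position carries a whole phenyl ring with growth inhibition holding level. Both compounds sit near the top of the scale at the single concentration tested, which limits how finely this comparison can separate them. No data here give a reason for this outcome.

Going by these compounds, it remains open whether a lower concentration would separate compound 1 from compound 3. Also open, on these data alone, is what an amine, a carboxylic acid or a longer chain such as phenethyl would do in the same place.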